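From phenyl to 2,3-dichlorophenyl: an expected step

The source may report more compounds than this note shows. Statements on the series, on what has been measured and on what is new or still open speak of the compounds shown alone.

Compound 1 `CNC(=O)c1cc(Oc2ccc(C(=O)/C=C/c3ccc([N+](=O)[O-])cc3)cc2)ccn1` gives > 50000 nM as a limit
Compound 2 `CNC(=O)c1cc(Oc2ccc(C(=O)/C=C/c3ccccc3)cc2)ccn1` gives 5040 nM as a number

For the measured compounds named here, in a functional assay on A549 cells (Homo sapiens) for cytotoxicity, read by MTT assay, with a stated time of 72 h (on this read-out higher numbers stand for weaker inhibition and lower numbers for stronger inhibition), compound 2 gives 5040 nM as the only actual number so far. Compound 1 gives > 50000 nM as a limit.

The change to compound 3 `CNC(=O)c1cc(Oc2ccc(C(=O)/C=C/c3cccc(Cl)c3Cl)cc2)ccn1` puts 2,3-dichlorophenyl in place of phenyl on a double-bonded chain carbon bound to a double-bonded chain carbon. Going by the values given here, one measured step bears on this same phenyl group: hydrogen in place of nitro gave an at least 9.9-fold lower number from compound 1 to compound 2 (0.99 log units; beyond the scatter) and was at least modest in size. That step involves nitro rather than chlorine and rests on a limit, so it sets no direction here, though it argues for a wide range. An expected step of a 1.3-fold lower number from compound 2 to compound 3 (0.10 log units; within the scatter) is estimated, with no change beyond the scatter anticipated. For compound 3 the expected value is 4000 nM (estimated range 1200 nM to 15000 nM).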

Compound 3, half-maximal inhibitory concentration: > 50000 nM
Compound 3 ended at the assay's limit; the forecaster's own chance of this, stated with the estimate: 10%; at least 12-fold (1.09 log units) between middle value and limit.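

In this assay, 2,3-dichlorophenyl in place of phenyl gave an at least 9.9-fold higher number from compound 2 to compound 3 (0.99 log units; beyond the scatter), so the loss seen earlier with nitro is not confined to that one group. Compound 1 and compound 3 both stand as limits, and the step between them cannot be read. Of the three groups shown at this position, 4-nitrophenyl, 2,3-dichlorophenyl and phenyl, only the phenyl of compound 2 gives an actual number, while the two substituted phenyl groups end at the same limit: the limit of > 50000 nM in this assay, at which 2 of the 3 values shown sit.

From the compounds shown here alone, whether a single chlorine, a methoxy group or an amine on this phenyl would also end at that limit remains open. So does whether a carboxylic acid or a longer chain at this position would give a number at all.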